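From 3-chlorobenzyl to 2-cyanobenzyl: a step under a limit

This account rests on a few compounds, and the source may have more. Where it says the series, first, only, none or still open, it means among the compounds named here.

In a toxicity assay on NIH3T3 cells (Mus musculus) for cytotoxicity, read by resazurin assay (on this read-out higher numbers stand for an effect only at larger amounts of compound and lower numbers for an effect already at smaller amounts), compound 3 (`COC(=O)c1ccc(NCc2cncn2Cc2cccc(Cl)c2)cc1-c1ccccc1`) gives > 10000 nM, which is a limit and not a number. Compound 1 (`COC(=O)c1ccc(NCc2cncn2Cc2ccc(N)cc2)cc1-c1ccccc1`) gives > 10000 nM, also a limit. Compound 2 (`COC(=O)c1ccc(NCc2cncn2Cc2cccc(C)c2)cc1-c1ccccc1`) gives > 10000 nM, again a limit. The whole set so far reads as the limit of > 10000 nM in this assay, at which 3 of the 3 values shown sit.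

Compound 4 (`COC(=O)c1ccc(NCc2cncn2Cc2ccccc2C#N)cc1-c1ccccc1`) carries 2-cyanophenyl in place of 3-chlorophenyl on a saturated chain carbon bound to an aromatic nitrogen.

The measured steps that bear on this change are a step that the two limits leave unreadable from compound 1 to compound 3, a step that the two limits leave unreadable from compound 1 to compound 2 and a step that the two limits leave unreadable from compound 2 to compound 3. None of them has a readable size, yet each exchange leaves the compound at the limit of this assay. On that basis, no shift beyond the scatter is expected, and no direction can be assigned. The expected change is a step that the limit leaves unreadable from compound 3 to compound 4. Compound 4 is estimated at 12000 nM, with an expected range of 5000 nM to 30000 nM, and a further limit is the most likely report.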

Compound 4, half-maximal effective concentration: 25000 nM
Estimate against measurement, compound 4: 2.1-fold (0.32 log units) below, within the range that was stated.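

Among these compounds, compound 1, compound 2 and compound 3 stand only as limits in this assay, so no step from any of them to compound 4 can be read. The compounds shown leave open whether any of these exchanges shifts the cytotoxicity at all, and in which direction.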